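The compounds below may be only part of what the source reports. "The series", "measured", "known", "first", "only" and "open" are said of these compounds alone.

Working notes on the series. In a functional assay on FM3A cells (Mus musculus) for cytotoxicity (on this read-out higher numbers stand for an effect only at larger amounts of compound and lower numbers for an effect already at smaller amounts), compound 1 (`Fc1ccc(C2OOC3CCCC(c4ccccc4)(OO2)O3)cc1`) gives 17000 nM. Compound 2 (`Fc1ccc(C23CCCC(OOC(C4CCCCC4)OO2)O3)cc1`) gives 2500 nM, the lower of the two numbers, with the gap beyond the scatter. Compound 3 (`Fc1ccc(C2OOC3CCCC(c4ccc(F)cc4)(OO2)O3)cc1`) is not yet measured. It has 4-fluorophenyl in place of cyclohexyl on a saturated ring carbon. Within the data shown here, no measured step isolates this change. Compound 3 lacks cyclohexyl, as does compound 1 at 17000 nM, so a move towards that number is expected. The expected step, a 3.6-fold higher number from compound 2 to compound 3 (0.56 log units; beyond the scatter), points to a higher number, beyond the scatter. For compound 3 the estimated value is 9000 nM, with an expected range of 3000 nM to 25000 nM.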

Compound 3, half-maximal effective concentration: 9000 nM
For compound 3 middle estimate and measured number coincide at the digits printed; low and high end bracket the measured number.
By their numbers in this assay, from the lowest: compound 2; then compounds 3 and 1 (each within the scatter of the next).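

In this assay, 4-fluorophenyl in place of cyclohexyl on a saturated ring carbon gives the first step read at this position (a 3.6-fold higher number from compound 2 to compound 3 (0.56 log units; beyond the scatter)), a modest change beyond the scatter. Fluoro in place of hydrogen on an aromatic carbon gives a step within the scatter (a 1.9-fold lower number from compound 1 to compound 3 (0.28 log units; within the scatter)), so no effect of this fluoro can be read. Nothing at hand gives a reason for either step. Open, as far as these compounds go, is how an amine or a carboxylic acid on this ring carbon would compare with cyclohexyl. Also open, from the compounds shown here alone, is whether a methyl or a longer alkyl chain there would stay near compound 2.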